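A few compounds are considered here, and "the series" means these few. Any claim that something is new, unique, unknown or untested is made for them only; others in the source may bear on it.

Three compounds share one core and differ in two places. Compound 1 `Oc1ccc2c(c1)CCC(NCCCc1ccccc1)CC2` gives 32 nM in an assay on membranes from liver for displacement of a labelled ligand from Sigma intracellular receptor 2 (Rattus norvegicus), read by scintillation counting, with stated times of 120 min and 5 min; a lower number here means a stronger inhibitor, a higher number a weaker inhibitor. Compound 2 `Oc1ccc2c(c1)CCC(NCCCCc1ccccc1)CC2` gives 96 nM in this assay. Compound 3 `OCc1ccc2c(c1)CCC(NCCCc1ccccc1)CC2` gives 592 nM in this assay, the highest number of the three, and its distance to each of the other two lies beyond the scatter. The step of a 19-fold higher number from compound 1 to compound 3 (1.27 log units; beyond the scatter) shows a large rise for hydroxymethyl in place of hydroxy, while the step of a 3.0-fold higher number from compound 1 to compound 2 (0.48 log units; beyond the scatter) shows a smaller rise for benzyl in place of phenyl. Compound 4 `OCc1ccc2c(c1)CCC(NCCCCc1ccccc1)CC2` has not yet been measured. It differs from compound 3 by benzyl in place of phenyl on a saturated chain carbon, three bonds along the chain from an amine nitrogen. Going by the values given here, the only measured step that bears on this change is a 3.0-fold higher number from compound 1 to compound 2 (0.48 log units; beyond the scatter), made on the hydroxy rather than the hydroxymethyl compounds. If that step carries over, compound 4 is expected to show a modest rise in this assay, by the step of a 3.0-fold higher number from compound 3 to compound 4 (0.48 log units; beyond the scatter). Compound 4 is therefore estimated at 1800 nM, with a range from 700 nM to 4500 nM that is kept wide, as a single example underlies the expectation.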

Compound 4, inhibition constant: 271 nM
Estimate against measurement, compound 4: 6.6-fold (0.82 log units) above; the measured number lies below the stated range.
By their numbers in this assay, from the lowest: compound 1; then compound 2; then compound 4; then compound 3.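

The change from phenyl to benzyl on a saturated chain carbon, three bonds along the chain from an amine nitrogen, has no fixed direction in this assay: with hydroxymethyl on the aromatic carbon it gives a 2.2-fold lower number from compound 3 to compound 4 (0.34 log units; beyond the scatter) and so reverses the rise seen with hydroxy. What this change does therefore depends on the group at the other place, and a step measured on one core did not carry over to the other: the same change on two cores in this assay, a 3.0-fold higher number (0.48 log units; beyond the scatter) from compound 1 to compound 2 and a 2.2-fold lower number (0.34 log units; beyond the scatter) from compound 3 to compound 4, 6.6-fold (0.82 log units) apart, beyond the scatter of two such steps. Seen from the other place, hydroxymethyl in place of hydroxy still raises the number with benzyl, but the step of a 2.8-fold higher number from compound 2 to compound 4 (0.45 log units; beyond the scatter) is much smaller than with phenyl: the same change on two cores in this assay, a 19-fold higher number (1.27 log units; beyond the scatter) from compound 1 to compound 3 and a 2.8-fold higher number (0.45 log units; beyond the scatter) from compound 2 to compound 4, 6.6-fold (0.82 log units) apart, beyond the scatter of two such steps.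

From the compounds shown here alone, it remains open whether this reversal also appears with another group on the aromatic carbon, such as methoxy or an amine. Going by these compounds, the effect of phenethyl in place of benzyl on either core also remains open.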